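Ester in place of ether on the chromone oxygen

The source may hold more compounds than are shown below. What is called first, only, known or untested is meant among the compounds shown, and "the series" means these compounds.

Of the compounds shown here, two have been measured in a functional assay on DLD-1 cells (Homo sapiens) for cytotoxicity, with a stated time of 48 h; a lower number here means a stronger inhibitor, a higher number a weaker inhibitor. Compound 1 `CCCOc1ccc2oc(/C=C/[S+](C)[O-])cc(=O)c2c1` gives 6200 nM there, and compound 2 `C[S+]([O-])/C=C/c1cc(=O)c2ccccc2o1`, which carries hydrogen in place of propoxy on an aromatic carbon, gives 8000 nM; the step of a 1.3-fold higher number from compound 1 to compound 2 (0.11 log units; within the scatter) is within the scatter, so the two numbers cannot be ordered.

Compound 3 `CCC(=O)Oc1ccc2oc(/C=C/[S+](C)[O-])cc(=O)c2c1` is not yet measured. It differs from compound 1 by propanoyl in place of propyl on an oxygen on an aromatic ring. Among the measured compounds shown here, no measured step alters the group on this oxygen; the only recorded step, a 1.3-fold higher number from compound 1 to compound 2 (0.11 log units; within the scatter), removes the propoxy altogether and stays within the scatter. There is thus no basis for expecting a shift in this assay beyond the scatter in either direction.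

The number for compound 3 is therefore estimated at 6500 nM, with a range of 3000 nM to 14000 nM. This estimate corresponds to an expected step of a 1.0-fold higher number from compound 1 to compound 3 (0.02 log units; within the scatter).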

Compound 3, half-maximal inhibitory concentration: 9000 nM
Estimate against measurement, compound 3: 1.4-fold (0.14 log units) below; measured number inside the range.
By their numbers in this assay, from the lowest: compounds 1, 2 and 3 (each within the scatter of the next).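

In this assay the change from propyl to propanoyl on the oxygen on the aromatic ring gives a 1.5-fold higher number from compound 1 to compound 3 (0.16 log units; within the scatter) so, at this level of activity, the ether and the ester cannot be told apart. Propanoyloxy in place of hydrogen on the aromatic carbon gives a 1.1-fold higher number from compound 2 to compound 3 (0.05 log units; within the scatter) and so the ester, like the propoxy, cannot be separated from hydrogen at this place. Nothing at hand explains why these numbers stay together.

From the compounds shown here alone, all three compounds lie within the scatter of one another, so it remains open whether any group at this place can move the number beyond it. A free hydroxyl, a longer chain such as octyl, or a chain ending in an amine could test this, and the compounds shown say nothing about how any of these would behave.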